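Replacing an Acetyl with a Thiophene Arm on the Ring Nitrogen

A few compounds are considered here, and "the series" means these few. Any claim that something is new, unique, unknown or untested is made for them only; others in the source may bear on it.

Three compounds have been measured in an ADME assay on cells (Hepatocyte, Rattus norvegicus) for metabolic stability; a lower number here means slower removal, a higher number faster removal of the compound:
Compound 1, `CN(C)C(=O)CN1CCC(c2cc3c(-c4ccc(=O)n(C)c4)ccnc3[nH]2)CC1`, gives < 1 uL/min, which is a limit of the assay rather than a number.
Compound 2, `CC(=O)N1CCC(c2cc3c(-c4ccc(=O)n(C(C)C)c4)ccnc3[nH]2)CC1`, gives 2.8 uL/min.
Compound 3, `COc1cc(F)ccc1-c1ccnc2[nH]c(C3CCN(C(C)=O)CC3)cc12`, gives 50 uL/min.

Of the two numbers, compound 2 stands at the lower end, and compound 3 sits higher by a gap that is beyond the usual scatter. Compound 4, `CC(C)n1cc(-c2ccnc3[nH]c(C4CCN(Cc5cccs5)CC4)cc23)ccc1=O`, has not yet been measured in this assay. It differs from compound 2 in one place: (thiophen-2-yl)methyl in place of acetyl on an amine nitrogen in a ring. Among the compounds with values here, no measured pair of compounds shows this change directly, so its effect here cannot be read off the data, and no step of this kind has been observed with these compounds. Nonetheless, a moderate rise in clearance is expected, the step from compound 2 to compound 4 being estimated as a 5.4-fold higher number from compound 2 to compound 4 (0.73 log units; beyond the scatter). Compound 4 is therefore expected to give about 15 uL/min in this assay, with a likely range from 4 uL/min to 60 uL/min.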

Compound 4, intrinsic clearance in a liver preparation (reported as CLH), per the amount of preparation that the assay uses: 43 uL/min
Compound 4: middle estimate off by 2.9-fold (0.46 log units), on the low side; low and high end bracket the measured number.
By their numbers in this assay, from the lowest: compound 2; then compounds 4 and 3 (each within the scatter of the next). At a limit, below all of these: compound 1.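

Within the data shown here, this is the only step here that changes a single place, and it shows that the group on the amine nitrogen in the ring has a large effect on the number in this assay, with a 15-fold higher number from compound 2 to compound 4 (1.19 log units; beyond the scatter). The rest of the structure is shared, so the whole step belongs to (thiophen-2-yl)methyl in place of acetyl. The low number of compound 2 therefore does not carry over to this replacement, although one replacement cannot show how other groups on this nitrogen would behave.

Nothing given here explains the rise. Going by these compounds, it also remains open whether the gain comes from the thiophene ring or simply from losing acetyl, a question that a benzyl group or a plain methyl on the same nitrogen could help to separate.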